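Adding One Carbon Twice: Does the Second Step Match?

A few compounds are considered here, and "the series" means these few. Any claim that something is new, unique, unknown or untested is made for them only; others in the source may bear on it.

Compound 1, `CCc1cccc2c(OC)c(-c3occ(C)c3CO)ccc12`, was tested in a functional assay on MDA-MB-231 cells (Homo sapiens) for cytotoxicity, read by MTT assay, with a stated time of 72 h; a higher number here means that more compound is needed for the effect, a lower number that less compound is needed. For compound 1 the result is only a limit, > 10 ug/mL, at the limit of > 10 ug/mL in this assay, at which 1 of the 3 values shown sits. Compound 2, `CCOc1c(-c2occ(C)c2CO)ccc2c(CC)cccc12`, differs from compound 1 by methyl in place of hydrogen on a saturated chain carbon bound to an oxygen on an aromatic ring, and in this assay compound 2 gives 1.4 ug/mL, a change of an at least 7.1-fold lower number from compound 1 to compound 2 (0.85 log units; beyond the scatter). Compound 3, `CCc1cccc2c(OC)c(-c3occ(C)c3COC)ccc12`, differs from compound 1 by methyl in place of hydrogen on an oxygen on a saturated carbon; in this assay compound 3 gives 9.7 ug/mL, which is an at least 1.0-fold lower number from compound 1 to compound 3 (0.01 log units; that floor lies within the scatter).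

Compound 4, `CCOCc1c(C)coc1-c1ccc2c(CC)cccc2c1OC`, is not yet measured. It differs from compound 3 by methyl in place of hydrogen on a saturated chain carbon bound to an oxygen on a saturated carbon. Among the measured compounds shown here, this is the same kind of change as the one from compound 1 to compound 2, but not at the same place: there the methyl entered on a saturated chain carbon bound to an oxygen on an aromatic ring, here on a saturated chain carbon bound to an oxygen on a saturated carbon. The cores of the two pairs differ by methyl in place of hydrogen on an oxygen on a saturated carbon.

The earlier step rests on a single pair, and the place differs, so a smaller change is expected here, a 2.8-fold lower number from compound 3 to compound 4 (0.44 log units; beyond the scatter). Compound 4 is estimated at 3.5 ug/mL, between 1 ug/mL and 10 ug/mL.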

Compound 4, concentration for half-maximal effect: 9.1 ug/mL
Estimate against measurement, compound 4: 2.6-fold (0.41 log units) below; measured number inside the range.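

In this assay, going from methoxymethyl to ethoxymethyl gives a 1.1-fold lower number from compound 3 to compound 4 (0.03 log units; within the scatter), so the two compounds cannot be told apart. The added methyl therefore does not carry a like-sized step from one place and core to the other: the same change on two cores in this assay, an at least 7.1-fold lower number (0.85 log units; beyond the scatter) from compound 1 to compound 2 and a 1.1-fold lower number (0.03 log units; within the scatter) from compound 3 to compound 4, at least 6.7-fold (0.82 log units) apart, beyond the scatter of two such steps. Compound 1 gives > 10 ug/mL, which is a limit and not a number. The step that rests on this limit is an at least 1.0-fold lower number from compound 1 to compound 4 (0.04 log units; that floor lies within the scatter), so it is only a floor and gives no measured size. These two single pairs show neither the reason for the gap nor a rule for other cores.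

On these data alone, it remains open what methoxy to ethoxy does on the core of compound 3, where the methoxymethyl stays in place, and so whether the earlier step depends on the core or on the place of the change. As far as these compounds go, it is also open whether a longer chain, such as propyl, on either oxygen, or an amine in place of the ether group, would follow either step.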